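Growing the chain on the ring nitrogen of compound 3

This account rests on a few compounds, and the source may have more. Where it says the series, first, only, none or still open, it means among the compounds named here.

Measured compounds:
compound 1 `CC(C)c1onc(-c2c(Cl)cccc2Cl)c1COc1ccc(-c2nc3ccc(C(=O)O)cc3n2C)cc1`, 7150 nM
compound 2 `CCCn1c(-c2ccc(OCc3c(-c4c(Cl)cccc4Cl)noc3C(C)C)cc2)nc2ccc(C(=O)O)cc21`, 1400 nM
compound 3 `CC(C)c1onc(-c2c(Cl)cccc2Cl)c1COc1ccc(-c2nc3ccc(C(=O)O)cc3n2CC2CC2)cc1`, 2650 nM

Three compounds share one core and differ only in the group on a saturated chain carbon bound to an aromatic nitrogen. In an assay on HEK-293T cells for antagonist activity at vitamin D3 receptor (Homo sapiens), read by a luciferase reporter, with a stated time of 24 h (a lower number here means a stronger inhibitor, a higher number a weaker inhibitor), compound 1 gives 7150 nM, compound 2 gives 1400 nM and compound 3 gives 2650 nM. Compound 3 thus holds the second highest number of the three: its step to compound 2, a 1.9-fold higher number from compound 2 to compound 3 (0.28 log units; within the scatter), lies within the scatter, while a 2.7-fold lower number from compound 1 to compound 3 (0.43 log units; beyond the scatter) and a 5.1-fold lower number from compound 1 to compound 2 (0.71 log units; beyond the scatter) were both beyond it and modest.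

Compound 4 `CC(=O)C1CCC(Cn2c(-c3ccc(OCc4c(-c5c(Cl)cccc5Cl)noc4C(C)C)cc3)nc3ccc(C(=O)O)cc32)CC1` is not yet measured. Its change from compound 3 is 4-acetylcyclohexyl in place of cyclopropyl on a saturated chain carbon bound to an aromatic nitrogen. The two steps that bear on it, a 2.7-fold lower number from compound 1 to compound 3 (0.43 log units; beyond the scatter) and a 1.9-fold higher number from compound 2 to compound 3 (0.28 log units; within the scatter), show that adding a small group at this place lowered the number modestly and that swapping cyclopropyl for ethyl changed little. Going by the values given here, no measured step reaches a group of this size or one carrying an acceptor, so the expectation is uncertain: compound 4 is estimated to give 1500 nM, within 400 nM to 6000 nM, meaning an expected 1.8-fold lower number from compound 3 to compound 4 (0.25 log units; within the scatter) in this assay.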

Compound 4, half-maximal inhibitory concentration: > 10000 nM
Compound 4: no number, only a limit; the forecaster's own chance of this, stated with the estimate: 5%; at least 6.6-fold (0.82 log units) between middle value and limit.
By their numbers in this assay, from the lowest: compounds 2 and 3 (each within the scatter of the next); then compound 1. At a limit, above all of these: compound 4.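

In this assay compound 4 gives > 10000 nM, which is a limit of the assay and not a number. The earlier compounds had shown only that ethyl and cyclopropyl in place of hydrogen on this saturated chain carbon lowered the number, whereas 4-acetylcyclohexyl in the same place reverses that, with an at least 3.7-fold higher number from compound 3 to compound 4 (0.57 log units; beyond the scatter) and an at least 7.1-fold higher number from compound 2 to compound 4 (0.85 log units; beyond the scatter), so enlarging the group here does not keep lowering it. The remaining step, an at least 1.3-fold higher number from compound 1 to compound 4 (0.14 log units; that floor lies within the scatter), has a floor within the scatter, so it does not set those two compounds apart.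

The compounds shown do not separate the part played by the cyclohexyl ring from that of its acetyl group, since both enter together. Going by these compounds, what a plain cyclohexyl, a longer chain or an amine at this place would give stays open.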